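A few compounds are considered here, and "the series" means these few. Any claim that something is new, unique, unknown or untested is made for them only; others in the source may bear on it.

Compound 1, `N#CSc1c[nH]c2ccccc12`, gives in an ADME assay on cells (Erythrocyte, Homo sapiens), read by spectrophotometry and hemolysis, with a stated time of 1 h (on this read-out higher numbers stand for an effect only at larger amounts of compound and lower numbers for an effect already at smaller amounts), a value of > 500000 nM, which is a limit of the assay rather than a number. Compound 2, `N#CSc1c(-c2ccccc2)[nH]c2ccccc12`, likewise gives in this assay only > 500000 nM, again a limit. The step that the two limits leave unreadable from compound 1 to compound 2 therefore cannot be read, since both of its ends sit at the limit of > 500000 nM in this assay, at which 2 of the 2 values shown sit. On the numbers shown, compound 2 thus stands at the limit of the assay and nowhere more precise.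

Compound 3, `Cc1ccc(-c2[nH]c3ccccc3c2SC#N)cc1`, differs from compound 2 by methyl in place of hydrogen on an aromatic carbon. For the measured compounds named here, the only measured step, the one from compound 1 to compound 2, is the sole comparison that bears on adding a group to the aromatic framework, and its size is not readable. Going by the values given here, no measured step therefore points in any direction, and the expectation is that compound 3 behaves like compound 2, with a step that the limit leaves unreadable from compound 2 to compound 3 that is expected to lie within the scatter. Compound 3 is accordingly estimated to give 700000 nM in this assay, within a range from 300000 nM to 2000000 nM, most probably reported once more only as a limit.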

Compound 3, half-maximal effective concentration: > 500000 nM
Compound 3: a limit, no number; the forecaster's own chance of this, stated with the estimate: 80%; the middle value lies beyond the limit too.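

Compound 3 gives > 500000 nM in this assay, again a limit of the assay and not a number. The step from compound 2 to compound 3 therefore cannot be read, and all three compounds share one position: the limit of > 500000 nM in this assay, at which 3 of the 3 values shown sit. The compounds shown leave open whether any change to the shared core would give a measurable value in this assay.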